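The source may hold more compounds than are shown below. What is called first, only, known or untested is meant among the compounds shown, and "the series" means these compounds.

Compound 1 `COc1cc2[nH]c(C)c(-c3ccncc3)c(=O)c2cc1Cl`: > 33300 nM
Compound 2 `COc1cc2[nH]c(C)c(-c3ccco3)c(=O)c2cc1Cl`: > 34500 nM
Compound 3 `COc1cc2[nH]c(C)c(-c3ccc(S(=O)(=O)N(C)C)cc3)c(=O)c2cc1Cl`: > 24600 nM

All three entries are limits of the assay, not exact numbers. In an ADME assay on J774 cells (Mus musculus) for cytotoxicity, with a stated time of 72 h (a higher number here means that more compound is needed for the effect, a lower number that less compound is needed), compound 3 gives > 24600 nM, which is a limit, and the other two compounds likewise stand only at limits.

Compound 4 `COc1cc2[nH]c(C)c(-c3ccc(-c4ccccc4)cc3)c(=O)c2cc1Cl` carries phenyl in place of dimethylsulfamoyl on an aromatic carbon.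

Among the compounds with values here, the one measured step that bears on this, a step that the two limits leave unreadable from compound 1 to compound 2, is also a change of group on an aromatic carbon, but it offers no size to carry over. No step beyond the usual scatter is therefore expected, in either direction.

Compound 4 is expected at about 26000 nM, with an estimated range of 9000 nM to 35000 nM. This estimate means an expected step that the limit leaves unreadable from compound 3 to compound 4.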

Compound 4, half-maximal effective concentration: > 26600 nM
Compound 4: no number, only a limit; the forecaster's own chance of this, stated with the estimate: 70%; middle value at least 1.0-fold (0.00 log units) away from the limit.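

Within the data shown here, compound 3 and compound 4 are both known only as limits, so no step between them can be read. The compounds shown leave open what concentration of any of them would actually give the half-maximal effect.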